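Aryl Group Returns to the Saturated Ring Carbon

The compounds below may be only part of what the source reports. "The series", "measured", "known", "first", "only" and "open" are said of these compounds alone.

Compound 2 `Cc1cc(O)c(C2=NN(c3ccc(S(N)(=O)=O)cc3)C(/C=C/c3ccccc3)C2)cc1Cl` gives, in a functional assay on KM12 cells (Homo sapiens) for antiproliferative activity, with a stated time of 48 h (on this read-out lower numbers stand for stronger inhibition of growth and higher numbers for weaker inhibition of growth), 34800 nM, the highest of the two numbers recorded; its nearest neighbour is compound 1 `Cc1cc(O)c(C2=NN(c3ccc(S(N)(=O)=O)cc3)C(c3ccccc3Cl)C2)cc1Cl`, which gives 3660 nM. Among the compounds with values here, the only measured step, a 9.5-fold higher number from compound 1 to compound 2 (0.98 log units; beyond the scatter), separates these two, and it is the step that bears on the change now considered. Compound 3 `COc1ccc(C2CC(c3cc(Cl)c(C)cc3O)=NN2c2ccc(S(N)(=O)=O)cc2)c(OC)c1OC` differs from compound 2 in one place: 2,3,4-trimethoxyphenyl in place of 2-phenylethenyl on a saturated ring carbon. As in compound 1, a six-membered aromatic ring of carbon only sits directly on the saturated ring carbon, the double bond outside aromatic rings leaving with the 2-phenylethenyl group, though the entering 2,3,4-trimethoxyphenyl group carries hydrogen-bond acceptors that the 2-chlorophenyl group of compound 1 lacks. Nothing measured shows what those acceptors do. Because of the step of a 9.5-fold higher number from compound 1 to compound 2 (0.98 log units; beyond the scatter), a return toward the number of compound 1 is expected, so for compound 3 a step of a 6.3-fold lower number from compound 2 to compound 3 (0.80 log units; beyond the scatter) is estimated. Compound 3 is expected to give 5500 nM, within 1500 nM to 20000 nM.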

Compound 3, concentration for total growth inhibition: 5100 nM
Compound 3: middle estimate off by 1.1-fold (0.03 log units), on the high side, and the stated range covers the measured number.
By their numbers in this assay, from the lowest: compounds 1 and 3 (each within the scatter of the next); then compound 2.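

In this assay, 2,3,4-trimethoxyphenyl in place of 2-phenylethenyl gives (a 6.8-fold lower number from compound 2 to compound 3 (0.83 log units; beyond the scatter)), so among these three compounds the two with a six-membered aromatic ring directly on the saturated ring carbon both have lower numbers than compound 2. The comparison with 2-chlorophenyl gives (a 1.4-fold higher number from compound 1 to compound 3 (0.14 log units; within the scatter)), so compounds 1 and 3 cannot be told apart here, and the three hydrogen-bond acceptors entering with the 2,3,4-trimethoxyphenyl group bring no difference from compound 1 that this read-out can resolve. Nothing available accounts for either step.

As far as these compounds go, whether an aromatic ring on this carbon is what matters remains open, and a cyclohexyl group or a plain methyl there would test that. From the compounds shown here alone, it is also open whether all of the methoxy groups can be removed without changing the number, as an unsubstituted phenyl would show.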